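A Methyl Added to the Phenyl Ring of Compound 3

This account rests on a few compounds, and the source may have more. Where it says the series, first, only, none or still open, it means among the compounds named here.

Of the compounds shown here, three sharing one core have been measured in a functional assay on A549 cells (Homo sapiens) for inhibition, read by MTT assay, with a stated time of 72 h; a lower number here means a stronger inhibitor, a higher number a weaker inhibitor. Compound 1 `Cc1ccc2c(c1)/C(=N/NC(=S)N1CCN(c3ccccc3)CC1)C(=O)N2` gives 9880 nM, compound 2 `O=C1Nc2ccc(Br)cc2/C1=N/NC(=S)N1CCN(c2ccccc2)CC1` gives 12300 nM, and compound 3 `O=C1Nc2ccc(Cl)cc2/C1=N/NC(=S)N1CCN(c2ccccc2)CC1` gives 7340 nM. Compound 3 sits at the lowest of the three numbers, but its separation from the others is slight: a 1.3-fold lower number from compound 1 to compound 3 (0.13 log units; within the scatter) and a 1.7-fold lower number from compound 2 to compound 3 (0.22 log units; within the scatter), while a 1.2-fold higher number from compound 1 to compound 2 (0.10 log units; within the scatter), so the three values cannot be told apart.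

Compound 4 `Cc1ccccc1N1CCN(C(=S)N/N=C2\C(=O)Nc3ccc(Cl)cc32)CC1` differs from compound 3 in one place: methyl in place of hydrogen on an aromatic carbon. The methyl sits on the phenyl ring, ortho to a large group, and the change read one bond further out is phenyl to 2-methylphenyl. Within the data shown here, none of the measured steps touches this ring; all three exchange a group on the other aromatic ring of the core, and each stayed within the scatter. Among the measured compounds shown here, no measured step therefore bears on the new methyl, and the three values give no direction to lean toward. The step from compound 3 to compound 4 is expected to be a 1.0-fold lower number from compound 3 to compound 4 (0.00 log units; within the scatter), nothing beyond the scatter. Compound 4 is accordingly estimated to give about 7300 nM in this assay, with a range from 3500 nM to 15000 nM.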

Compound 4, half-maximal inhibitory concentration: 6520 nM
Estimate against measurement, compound 4: 1.1-fold (0.05 log units) above, within the range that was stated.
By their numbers in this assay, from the lowest: compounds 4, 3, 1 and 2 (each within the scatter of the next).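

In this assay, the change from phenyl to 2-methylphenyl gives a 1.1-fold lower number from compound 3 to compound 4 (0.05 log units; within the scatter), so a methyl ortho to a large group on this ring leaves compound 4 indistinguishable from compound 3. Among these compounds, this is the first measured change on the phenyl ring, and like the three exchanges on the other aromatic ring of the core, it stays within the scatter, so no change in either place has yet separated one compound from another. Nothing measured here speaks to why the methyl leaves the number within the scatter, and no supporting data accompany the result.

The compounds shown leave open whether this ring would respond to a group other than methyl, such as a longer chain like propyl, an amine or a carboxylic acid, since a single added carbon tests only a small part of what could stand at this place. They also leave open whether a methyl placed elsewhere on the phenyl ring, or a methoxy group at this same place, would give a step beyond the scatter.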